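Trifluoromethylphenyl amine swap carried onto a second core

The source may report more compounds than this note shows. Statements on the series, on what has been measured and on what is new or still open speak of the compounds shown alone.

Three compounds have numbers in a functional assay on ECa-109 cells (Homo sapiens) for inhibition, read by MTT assay, with a stated time of 72 h; on this read-out lower numbers stand for stronger inhibition and higher numbers for weaker inhibition. Compound 2 `Cc1ccc(Nc2nc(SCc3cn(CC(=O)NC(=O)Nc4ccccn4)nn3)nc(-c3ccc(C(C)C)cc3)c2C#N)cc1` gives 6700 nM. Compound 1 `CC(C)c1ccc(-c2nc(SCc3cn(CC(=O)NC(=O)Nc4ccccn4)nn3)nc(Nc3cccc(C(F)(F)F)c3)c2C#N)cc1` gives 24200 nM. Compound 3 `Cc1ccc(Nc2nc(SCc3cn(CC(=O)NC(=O)Nc4ccccn4)nn3)nc(-c3ccc(Br)cc3)c2C#N)cc1` gives 7920 nM. Compound 4 `N#Cc1c(Nc2cccc(C(F)(F)F)c2)nc(SCc2cn(CC(=O)NC(=O)Nc3ccccn3)nn2)nc1-c1ccc(Br)cc1` has not been measured.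

The change from compound 3 to compound 4 is 3-(trifluoromethyl)phenyl in place of 4-methylphenyl on a nitrogen on an aromatic ring. The same change has been made once before, from compound 2 to compound 1, as 3-(trifluoromethyl)phenyl in place of 4-methylphenyl on a nitrogen on an aromatic ring, and it gave a 3.6-fold higher number from compound 2 to compound 1 (0.56 log units; beyond the scatter). The two cores differ by bromo in place of isopropyl on an aromatic carbon, a step of a 1.2-fold higher number from compound 2 to compound 3 (0.07 log units; within the scatter), within the scatter. The place of the change reads the same word for word on both cores.

For compound 4 a step of a 3.3-fold higher number from compound 3 to compound 4 (0.52 log units; beyond the scatter) in this assay is expected, beside the earlier one; this rests on the single earlier occurrence, a 3.6-fold higher number from compound 2 to compound 1 (0.56 log units; beyond the scatter), and on the two cores standing within the scatter of each other. Compound 4 is estimated at 26000 nM, expected between 10000 nM and 70000 nM.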

Compound 4, half-maximal inhibitory concentration: 2960 nM
Compound 4: middle estimate off by 8.8-fold (0.94 log units), on the high side; measured number below the stated range.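

In this assay the change to 3-(trifluoromethyl)phenyl gives a 2.7-fold lower number from compound 3 to compound 4 (0.43 log units; beyond the scatter), so the direction seen on the core of compound 2 does not carry over to the core of compound 3: the same change on two cores in this assay, a 3.6-fold higher number (0.56 log units; beyond the scatter) from compound 2 to compound 1 and a 2.7-fold lower number (0.43 log units; beyond the scatter) from compound 3 to compound 4, 9.7-fold (0.99 log units) apart, beyond the scatter of two such steps.

Read the other way, bromo in place of isopropyl gives an 8.2-fold lower number from compound 1 to compound 4 (0.91 log units; beyond the scatter) with 3-(trifluoromethyl)phenyl on the nitrogen, a much larger step than with 4-methylphenyl there: the same change on two cores in this assay, a 1.2-fold higher number (0.07 log units; within the scatter) from compound 2 to compound 3 and an 8.2-fold lower number (0.91 log units; beyond the scatter) from compound 1 to compound 4, 9.7-fold (0.99 log units) apart, beyond the scatter of two such steps.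

The two changes therefore do not add independently across these four compounds, though the data do not show what lies behind this or whether it extends to other members of the series.

Open, going by these compounds, is whether chloro or methoxy in place of bromo would behave like compound 4 or like compound 1. Also open, on these data alone, is how an unsubstituted phenyl on the nitrogen would behave on either core.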